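Adding a 2-methylphenyl Where Only a Hydrogen Stood

The source may report more compounds than this note shows. Statements on the series, on what has been measured and on what is new or still open speak of the compounds shown alone.

Compound 1 `O=C1C[C@H]2O[C@H]([C@H](O)c3ccccc3)[C@H](O)[C@H]2O1` and compound 2 `O=C1C[C@H]2O[C@H](Cc3ccccc3)[C@H](O)[C@H]2O1` share a core and differ only in what sits on a saturated chain carbon bound to an aromatic carbon and a saturated ring carbon. In a functional assay on K562 cells (Homo sapiens) for antiproliferative activity, read by MTT assay, with a stated time of 72 h (a higher number here means a weaker inhibitor, a lower number a stronger inhibitor), compound 1 gives 410 nM, and in this assay compound 2 gives 510 nM. The step of a 1.2-fold higher number from compound 1 to compound 2 (0.09 log units; within the scatter) is the only one measured. Among the two numbers, compound 2 holds the higher one, with compound 1 nearest and within the scatter of it.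

Compound 3 `Cc1ccccc1[C@H](c1ccccc1)[C@H]1O[C@@H]2CC(=O)O[C@@H]2[C@H]1O` is not yet measured and differs from compound 2 by 2-methylphenyl in place of hydrogen on a saturated chain carbon bound to an aromatic carbon and a saturated ring carbon. Within the data shown here, no measured step involves an aromatic group entering at this place; the one step there, hydroxy to hydrogen, stayed within the scatter. He therefore expects in this assay a step of a 1.3-fold higher number from compound 2 to compound 3 (0.11 log units; within the scatter) that need not exceed the scatter, and estimates compound 3 at 650 nM, ranging from 200 nM to 2500 nM.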

Compound 3, half-maximal inhibitory concentration: 1560 nM
Beside the measured number, compound 3's estimate is 2.4-fold (0.38 log units) below it; low and high end bracket the measured number.
By their numbers in this assay, from the lowest: compounds 1 and 2 (each within the scatter of the next); then compound 3.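

This position had shown nothing beyond the scatter when hydroxy gave way to hydrogen, but in this assay it does respond to an added aromatic group: 2-methylphenyl in place of hydrogen gives a 3.1-fold higher number from compound 2 to compound 3 (0.49 log units; beyond the scatter) and marks a modest loss of activity. Set against hydroxy at the same carbon, the same group gives a 3.8-fold higher number from compound 1 to compound 3 (0.58 log units; beyond the scatter) and is also modest, so both steps into compound 3 lie beyond the scatter. Nothing in the data at hand explains this weakening.

Going by these compounds, how a plain phenyl, an amine or a carboxylic acid at this carbon would read in this assay stays open. Also open, on these data alone, is whether the methyl of the 2-methylphenyl contributes to the step at all, and how the opposite configuration at this carbon would compare.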